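The compounds below may be only part of what the source reports. "The series", "measured", "known", "first", "only" and "open" are said of these compounds alone.

Working notes on the series, all read in a functional assay on PC-3 cells (Homo sapiens) for antiproliferative activity, read by MTT assay, with a stated time of 72 h; a lower number here means a stronger inhibitor, a higher number a weaker inhibitor. Compound 1 (`O=C(N/N=C/c1ccc(O)cc1)Nc1ccc(Oc2ccnc3[nH]ccc23)cc1`) gives 4920 nM and compound 2 (`CN(C)CCn1cccc1/C=N/NC(=O)Nc1ccc(Oc2ccnc3[nH]ccc23)c(F)c1`) gives 1600 nM on the same read-out. Compound 3 (`CN(C)CCn1cccc1/C=N/NC(=O)Nc1ccc(Oc2ccnc3[nH]ccc23)cc1`) gives 3930 nM here, which places it within the scatter of compound 1 and beyond the scatter of compound 2, the lowest number of the three.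

Compound 4 (`CCN(CC)CCn1cccc1/C=N/NC(=O)Nc1ccc(Oc2ccnc3[nH]ccc23)cc1`) has not yet been measured. It has diethylamino in place of dimethylamino on a saturated chain carbon, two bonds along the chain from an aromatic nitrogen.

Among the compounds with values here, no measured step changes this amino group, so the evidence is indirect. Replacing the whole 4-hydroxyphenyl with 1-(2-(dimethylamino)ethyl)-1H-pyrrol-2-yl gave only a small shift (a 1.3-fold lower number from compound 1 to compound 3 (0.10 log units; within the scatter)). Within the data shown here, the only step beyond the scatter is modest and lies elsewhere, at hydrogen in place of fluoro on an aromatic carbon (a 2.5-fold higher number from compound 2 to compound 3 (0.39 log units; beyond the scatter)). Neither step indicates a direction for the new change, so no shift beyond the scatter is expected in this assay. The estimated step is small and of no firm direction (a 1.0-fold lower number from compound 3 to compound 4 (0.01 log units; within the scatter)). The expected value for compound 4 is 3800 nM (estimated range 1900 nM to 7500 nM).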

Compound 4, half-maximal inhibitory concentration: 1370 nM
Compound 4: middle estimate off by 2.8-fold (0.44 log units), on the high side; measured number outside the range, below it.
By their numbers in this assay, from the lowest: compounds 4 and 2 (each within the scatter of the next); then compounds 3 and 1 (each within the scatter of the next).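

At the terminal amine of the 2-(dimethylamino)ethyl chain, diethylamino (5 heavy atoms) in place of dimethylamino (3 heavy atoms) moves the number in this assay beyond the scatter (a 2.9-fold lower number from compound 3 to compound 4 (0.46 log units; beyond the scatter)). Within the data shown here, this is the first sign that the series responds to a change at this position, on a saturated chain carbon, two bonds along the chain from an aromatic nitrogen. The much larger exchange of the whole 4-hydroxyphenyl for 1-(2-(dimethylamino)ethyl)-1H-pyrrol-2-yl stayed within the scatter (a 1.3-fold lower number from compound 1 to compound 3 (0.10 log units; within the scatter)), so the size of the replaced group does not by itself set the size of the step in these compounds, and the outer end of the chain matters more than that exchange suggested. Nothing among the data available here explains the shift.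

The compounds shown leave open whether the lower number continues with dipropylamino or holds with the amine closed into a ring, as in pyrrolidine, piperidine or morpholine. They also leave open whether a propyl link in place of the ethyl link changes the step, and whether fluoro on the aromatic carbon adds to diethylamino.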